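A few compounds are considered here, and "the series" means these few. Any claim that something is new, unique, unknown or untested is made for them only; others in the source may bear on it.

In a functional assay on NCI-H460 cells (Homo sapiens) for inhibition, read by MTT assay, with a stated time of 72 h (a higher number here means a weaker inhibitor, a lower number a stronger inhibitor), compound 1 `COc1cc(NC(C)CCCNC(=O)Nc2ccc(Br)cc2)c2ncccc2c1` gives 30000 nM and compound 3 `COc1cc(NC(C)CCCNC(=O)Nc2cccc(O)c2)c2ncccc2c1` gives 25000 nM while compound 2 `COc1cc(NC(C)CCCNC(=O)NNC(=O)Nc2ccc(Cl)cc2)c2ncccc2c1` gives 63000 nM as the highest number of the three, which makes it the weakest inhibitor here. Compound 4 `COc1cc(NC(C)CCCNC(=O)Nc2cccc(C(F)(F)F)c2)c2ncccc2c1` is still unmeasured. Going from compound 2 to compound 4 brings this change: 3-(trifluoromethyl)phenyl in place of ((4-chlorophenyl)carbamoyl)amino on an amide-type nitrogen in which 3-(trifluoromethyl)phenyl replaces ((4-chlorophenyl)carbamoyl)amino on an amide-type nitrogen. Compound 4 thus carries a substituted phenyl on that nitrogen, like compound 1 and compound 3. Two modest measured steps bear on this: a 2.5-fold lower number from compound 2 to compound 3 (0.40 log units; beyond the scatter) is one, a 2.1-fold higher number from compound 1 to compound 2 (0.32 log units; beyond the scatter) is the other when read in reverse, and a 1.2-fold lower number from compound 1 to compound 3 (0.08 log units; within the scatter) stays within the scatter. A step of a 2.5-fold lower number from compound 2 to compound 4 (0.40 log units; beyond the scatter) is therefore expected in this assay toward a lower number. Compound 4 is estimated at 25000 nM with an expected range of 10000 nM to 60000 nM in this read-out.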

Compound 4, half-maximal inhibitory concentration: 21000 nM
For compound 4 the middle estimate is 1.2-fold (0.08 log units) above the measured one; the measured number falls inside the stated range.
By their numbers in this assay, from the lowest: compounds 4, 3 and 1 (each within the scatter of the next); then compound 2.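

In this assay, a third substituted phenyl group on this amide-type nitrogen gives no separation from the other two: trifluoromethyl in place of hydroxy gives (a 1.2-fold lower number from compound 3 to compound 4 (0.08 log units; within the scatter)), and 3-(trifluoromethyl)phenyl in place of 4-bromophenyl gives (a 1.4-fold lower number from compound 1 to compound 4 (0.15 log units; within the scatter)). Among these compounds, only ((4-chlorophenyl)carbamoyl)amino differs from these groups, and this new comparison is the largest step so far (a 3.0-fold lower number from compound 2 to compound 4 (0.48 log units; beyond the scatter)). No measurement shown explains that difference. Still open, on these data alone, is how an amine or a carboxylic acid on the phenyl ring would read in this assay, and whether any such group would give a number clearly lower than those of compounds 1, 3 and 4.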